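A few compounds are considered here, and "the series" means these few. Any claim that something is new, unique, unknown or untested is made for them only; others in the source may bear on it.

In a functional assay on RAW264.7 cells (Mus musculus) for inhibition, with stated times of 2 h and 24 h (a higher number here means a weaker inhibitor, a lower number a stronger inhibitor), compound 1 (`O=C1c2cc(O)cc(O)c2[C@@H](c2ccc(O)cc2)[C@@H]1c1cc(O)cc(O)c1`) gives only a limit, > 200000 nM. Compound 2 (`COc1ccc([C@@H]2c3c(OC)cc(OC)cc3C(=O)[C@H]2c2cc(OC)cc(OC)c2)cc1`) also gives only a limit, > 200000 nM. Among the measured compounds shown here, compound 3 (`COc1ccc(/C=C2/c3cc(OC)cc(OC)c3[C@@H](c3ccc(OC)cc3)[C@@H]2c2cc(OC)cc(OC)c2)cc1`) gives 6260 nM, the only actual number among the three compounds measured so far. Compound 4 (`COc1ccc([C@@H]2c3c(OC)cc(OC)cc3/C(=C/c3ccccc3)[C@H]2c2cc(OC)cc(OC)c2)cc1`) departs from compound 3 by a single change, hydrogen in place of methoxy on an aromatic carbon, para to a large group, so that 4-methoxyphenyl becomes phenyl. For the measured compounds named here, no measured pair shows the size of such a change. The expected step of a 1.4-fold higher number from compound 3 to compound 4 (0.16 log units; within the scatter) is small, slightly toward weaker inhibition in this assay but not beyond the scatter. For compound 4, the estimated value is 9000 nM, with an expected range of 3000 nM to 30000 nM.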

Compound 4, half-maximal inhibitory concentration: > 200000 nM
Compound 4 was reported as a limit (the forecaster's own chance of this, stated with the estimate: 10%); middle value at least 22-fold (1.34 log units) away from the limit.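

Among the compounds shown here, the earlier compounds offered no pair differing in one place, so this is the first direct reading of a single change. In this assay, replacing 4-methoxyphenyl with phenyl gives an at least 31-fold higher number from compound 3 to compound 4 (1.50 log units; beyond the scatter), which shows that measurable inhibition in this pair depends on the methoxy on this aromatic carbon, para to a large group. Compound 4 gives only a limit, so the step has a lower bound and no known upper end: the limit of > 200000 nM in this assay, at which 3 of the 4 values shown sit.

From the compounds shown here alone, it remains open whether methoxy itself is needed or whether another group here, such as ethoxy, fluorine or an amine, would serve as well.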